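The compounds below may be only part of what the source reports. "The series", "measured", "known", "first", "only" and "open" are said of these compounds alone.

Measured so far in an assay on isolated protein for inhibition of Neuropeptide Y receptor type 5 (Mus musculus); on this read-out lower numbers stand for stronger inhibition and higher numbers for weaker inhibition: compound 1 `Cc1ccccc1C(=O)c1cnc(NCCCNS(=O)(=O)c2cccc(F)c2)s1` gives 5.5 nM; compound 2 `COc1ccc(C)cc1S(=O)(=O)NCCCNc1ncc(C(=O)c2ccccc2C)s1` gives 0.71 nM.

Within the data shown here, compound 2 has the lowest of the two numbers; the nearest is compound 1, with a 7.7-fold lower number from compound 1 to compound 2 (0.89 log units; beyond the scatter) as the only measured step, a change on the sulfonyl sulfur. Compound 3 `COc1ccc(OC)c(S(=O)(=O)NCCCNc2ncc(C(=O)c3ccccc3C)s2)c1` differs from compound 2 by methoxy in place of methyl on an aromatic carbon, read one bond further out as 2-methoxy-5-methylphenyl to 2,5-dimethoxyphenyl. Among the measured compounds shown here, no measured step isolates this methyl, so the aryl change in compound 1 to compound 2 bears on it only loosely. Expectation for compound 3: a step of a 1.3-fold higher number from compound 2 to compound 3 (0.10 log units; within the scatter), within the scatter, estimated at 0.9 nM (range 0.3 nM to 3 nM).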

Compound 3, half-maximal inhibitory concentration: 1.6 nM
Estimate against measurement, compound 3: 1.8-fold (0.25 log units) below, and the stated range covers the measured number.
By their numbers in this assay, from the lowest: compound 2; then compound 3; then compound 1.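

In this assay, the position para to a methoxy group responds to a single-group change: methoxy in place of methyl gives a weaker result (a 2.3-fold higher number from compound 2 to compound 3 (0.35 log units; beyond the scatter)), which the earlier aryl swap could not isolate. The 2,5-dimethoxyphenyl group still keeps an advantage over 3-fluorophenyl (a 3.4-fold lower number from compound 1 to compound 3 (0.54 log units; beyond the scatter)). No available evidence accounts for either step.

Still open, from the compounds shown here alone, is how an ethoxy, an amine or a carboxylic acid would read at this position. Also open, going by these compounds, is whether plain hydrogen there would match methyl or methoxy.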